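Resorcinol isoxazole series: a pyrazole replaces the ester isoxazole

The source may hold more compounds than are shown below. What is called first, only, known or untested is meant among the compounds shown, and "the series" means these compounds.

Measured compounds in a functional assay on HCT-116 cells (Homo sapiens) for inhibition; a higher number here means a weaker inhibitor, a lower number a stronger inhibitor:
compound 1 `CCNCc1cc(-c2c(C(=O)NCC)noc2-c2cc(C(C)C)c(O)cc2O)on1`, 45 nM
compound 2 `CCNC(=O)c1noc(-c2cc(C(C)C)c(O)cc2O)c1-c1cc(CN(C)C)no1`, 92 nM
compound 3 `CCNC(=O)c1noc(-c2cc(C(C)C)c(O)cc2O)c1-c1cc(C(=O)OCC)no1`, "not determined" (no result reported)

Compound 3 stands outside the numbers: in this assay it has no value, so its place relative to compound 1 and compound 2 cannot be given. Among the measured compounds shown here, the only step within the measured set is a 2.0-fold higher number from compound 1 to compound 2 (0.31 log units; beyond the scatter), a modest change that touches the chain on the outer ring and not the ring itself.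

Compound 4 `CCNC(=O)c1noc(-c2cc(C(C)C)c(O)cc2O)c1-c1ccn(C(C)C)n1` differs from compound 3 by 1-isopropyl-1H-pyrazol-3-yl in place of 3-(ethoxycarbonyl)-1,2-oxazol-5-yl on an aromatic carbon. For the measured compounds named here, no measured pair covers a change of this kind; the step from compound 1 to compound 2 concerns a different part of the molecule and says nothing direct about exchanging the outer ring. The shared core is unchanged, and both measured compounds with this core fall in the same region of this assay.

Going by the values given here, without a value for compound 3, no step in this assay can be predicted for the change to compound 4; only an absolute expectation is possible. On the basis of compound 1 at 45 nM and compound 2 at 92 nM, compound 4 is estimated at 100 nM, with a range from 30 nM to 400 nM.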

Compound 4, half-maximal inhibitory concentration: 19 nM
For compound 4 the middle estimate is 5.3-fold (0.72 log units) above the measured one; the whole stated range lies above it.
By their numbers in this assay, from the lowest: compound 4; then compound 1; then compound 2.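

In this assay, the outer ring at this position does not need an aminomethyl chain to give a low number: 1-isopropyl-1H-pyrazol-3-yl, with no amine nitrogen in a side chain, gives a 4.8-fold lower number from compound 2 to compound 4 (0.69 log units; beyond the scatter) and a 2.4-fold lower number from compound 1 to compound 4 (0.37 log units; beyond the scatter), both beyond the scatter. This places compound 4 lowest of the three measured compounds and shows that the five-membered aromatic ring on this carbon can be exchanged, not only the chain it carries, while the number in this assay still falls. The step from compound 3 cannot be read, so the effect of replacing 3-(ethoxycarbonyl)-1,2-oxazol-5-yl stays unknown, and no measurement on hand accounts for the lower number of compound 4.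

The compounds shown do not separate the contribution of the pyrazole ring from that of its isopropyl group, a question that a methyl group, a cyclopropyl group or an aminoethyl chain at the same ring nitrogen would address. Also open, as far as these compounds go, is how a carboxylic acid or a primary amide on the outer ring would compare with these compounds in this assay.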